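A Thioether Analogue Follows the Methoxymethyl Lead

The compounds below may be only part of what the source reports. "The series", "measured", "known", "first", "only" and "open" are said of these compounds alone.

Compound 1 `Cc1cn2cccc(OCc3ccccc3)c2n1` is the starting point; in a functional assay on the whole organism with Rattus norvegicus as the target, with a stated time of 4 h, at a dose of 40 mg/kg by the intraperitoneal route (a lower number here means less inhibition, a higher number more inhibition at the dose given (going by the name of the read-out)), compound 1 gives 62%, the second highest of three numbers. Compound 2 `Cc1nc2c(OCc3ccccc3)cccn2c1C(N)=O` gives 42% in this assay, the step of a number 20 percentage points lower from compound 1 to compound 2 (beyond the scatter) being modest. Compound 3 `COCc1c(C)nc2c(OCc3ccccc3)cccn12` gives 99% in this assay, and the step of a number 37 percentage points higher from compound 1 to compound 3 (beyond the scatter) is large. Compound 4 `CSCc1c(C)nc2c(OCc3ccccc3)cccn12` differs from compound 1 by (methylsulfanyl)methyl in place of hydrogen on an aromatic carbon. The step of a number 37 percentage points higher from compound 1 to compound 3 (beyond the scatter) bears on it most closely: there, too, a group entered in place of hydrogen on an aromatic carbon, and the step of a number 57 percentage points higher from compound 2 to compound 3 (beyond the scatter) points the same way. A large rise is therefore expected, a number 23 percentage points higher from compound 1 to compound 4 (beyond the scatter). Compound 4 is expected to give about 85% in this assay, within 55% to 100%.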

Compound 4, a percentage reported as inhibition, in the whole organism at one dose (the size of the read-out at that dose, not a potency): 29%
Compound 4: middle estimate off by 56 percentage points, on the high side; measured number outside the range, below it.
By their numbers in this assay, from the lowest: compound 4; then compound 2; then compound 1; then compound 3.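

At this position, the outcome in this assay depends on the end of the chain and not merely on a chain being present: methylsulfanyl in place of methoxy gives a number 70 percentage points lower from compound 3 to compound 4 (beyond the scatter) on the same saturated chain carbon. Filling the position with (methylsulfanyl)methyl gives a number 33 percentage points lower from compound 1 to compound 4 (beyond the scatter) against hydrogen, opposite in direction to the methoxymethyl step. Against carbamoyl, the same group gives a number 13 percentage points lower from compound 2 to compound 4 (beyond the scatter) in this comparison.

Nothing available here accounts for the reversal. Going by these compounds, whether a hydroxymethyl group, an aminomethyl group or a longer ether chain would follow compound 3 or compound 4 remains open.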